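This account rests on a few compounds, and the source may have more. Where it says the series, first, only, none or still open, it means among the compounds named here.

Working notes on the series. The shared core is seen in compound 1 `COc1cccc(/C=C/C(=O)N2CCC=CS2(=O)=O)c1` and compound 2 `O=C(/C=C/c1cccc(-c2ccccc2)c1)N1CCC=CS1(=O)=O`; both were run in a functional assay on HeLa cells (Homo sapiens) for inhibition, read by sulforhodamine B assay, with a stated time of 48 h; on this read-out higher numbers stand for weaker inhibition of growth and lower numbers for stronger inhibition of growth. Compound 1 gives 23700 nM in this assay, and compound 2 gives 19800 nM in this assay. Of the two numbers, compound 2 holds the lower one, but the step of a 1.2-fold lower number from compound 1 to compound 2 (0.08 log units; within the scatter) shows the two compounds cannot be separated on the scatter. Compound 3 `O=C(/C=C/c1cccc(C(F)(F)F)c1)N1CCC=CS1(=O)=O` carries trifluoromethyl in place of phenyl on an aromatic carbon. Within the data shown here, no measured step involves a trifluoromethyl anywhere; the only step at this aromatic carbon, a 1.2-fold lower number from compound 1 to compound 2 (0.08 log units; within the scatter), stayed within the scatter, and it swapped a different pair of groups. With nothing pointing either way, the expected step in this assay is a 1.1-fold higher number from compound 2 to compound 3 (0.03 log units; within the scatter), which is none beyond the scatter. Compound 3 is therefore estimated at 21000 nM in this assay, with a range from 8000 nM to 55000 nM.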

Compound 3, concentration for 50% growth inhibition: 19600 nM
Beside the measured number, compound 3's estimate is 1.1-fold (0.03 log units) above it, within the range that was stated.
By their numbers in this assay, from the lowest: compounds 3, 2 and 1 (each within the scatter of the next).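

In this assay the step of a 1.0-fold lower number from compound 2 to compound 3 (0.00 log units; within the scatter) shows that trifluoromethyl, with no ring and 4 heavy atoms, can stand in place of phenyl, with its six-membered aromatic ring and 6 heavy atoms, on this aromatic carbon, meta to a large group, with no change that can be separated from the scatter. The step of a 1.2-fold lower number from compound 1 to compound 3 (0.08 log units; within the scatter) is also within the scatter, so methoxy, phenyl and trifluoromethyl at this position now give numbers that cannot be told apart in this assay and no order among these three compounds can be drawn. Nothing at hand bears on why the three groups give such similar numbers.

From the compounds shown here alone, whether an amine, a carboxylic acid or a longer chain on this aromatic carbon would give a step beyond the scatter remains open. Also open, going by these compounds, is whether a change elsewhere on the shared core would move the number in this assay when the group at this position stays the same.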